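Tetrahydropyridinyl in place of methylpyrazolyl on a weak core

The compounds below may be only part of what the source reports. "The series", "measured", "known", "first", "only" and "open" are said of these compounds alone.

Compound 1 `CC(c1cc2cccnc2cc1F)n1cnc2ncc(-c3cnn(C)c3)nc21` gives 31.3 nM in a functional assay on NCI-H1993 cells (Homo sapiens) for inhibition, read by CCK-8 assay, with a stated time of 72 h; a lower number here means a stronger inhibitor, a higher number a weaker inhibitor. Compound 2 `Cn1nccc1-c1cnc2ncn(Cc3ccc4ncccc4c3)c2n1` gives 7910 nM in this assay, the higher of the two reported numbers; the difference between compound 1 and compound 2 lies beyond the scatter. Compound 3 `CCC(c1ccc2ncccc2c1F)n1cnc2ncc(-c3cnc4ccccc4c3)nc21` gives "not determined" (no result reported) in this assay, that is, no result is reported for it.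

Compound 4 `C1=C(c2cnc3ncn(Cc4ccc5ncccc5c4)c3n2)CCNC1` is compound 2 with the change (a group of 6 heavy atoms (5 carbon, 1 nitrogen; one six-membered non-aromatic ring with 1 hetero atom) in place of a group of 6 heavy atoms (4 carbon, 2 nitrogen; one five-membered aromatic ring with 2 hetero atoms), on an aromatic carbon). For the measured compounds named here, no measured pair in the set shows this change, so nothing in the numbers points to its size or direction; the only anchor is the weak value of compound 2. The step of a 1.3-fold lower number from compound 2 to compound 4 (0.12 log units; within the scatter) is therefore expected to stay within the scatter. For compound 4 the estimate in this assay is 6000 nM, with a range of 1500 nM to 25000 nM.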

Compound 4, half-maximal inhibitory concentration: 6660 nM
Compound 4: middle estimate off by 1.1-fold (0.05 log units), on the low side; low and high end bracket the measured number.
By their numbers in this assay, from the lowest: compound 1; then compounds 4 and 2 (each within the scatter of the next).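

In this assay, placing the six-membered non-aromatic ring with 1 hetero atom at this aromatic carbon, in place of 1-methyl-1H-pyrazol-5-yl, gives a 1.2-fold lower number from compound 2 to compound 4 (0.07 log units; within the scatter) on this core. The five-membered aromatic ring is therefore not needed for the reading here, and the added hydrogen-bond donor brings no change beyond the scatter. Nothing available explains this result.
On these data alone, whether the exchange reads the same on the core of compound 1, at 31.3 nM, remains open. So does the effect of a simple amine or a carboxylic acid at this carbon.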